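Swapping Acetyl for Benzyl on the Ring Nitrogen

A few compounds are considered here, and "the series" means these few. Any claim that something is new, unique, unknown or untested is made for them only; others in the source may bear on it.

Measured compounds in a functional assay on the whole organism with Rattus norvegicus as the target, at a dose of 40 mg/kg by the intraperitoneal route; on this read-out lower numbers stand for less inhibition and higher numbers for more inhibition at the one dose given (going by the name of the read-out):
compound 1 `CC(C)(C)c1nc2c(OCc3ccccc3)cccn2c1N`: 0%
compound 2 `Cc1nc2cc(CCc3ccccc3)ccn2c1N`: 50%
compound 3 `CC(=O)Nc1c(C)nc2c(OCc3ccccc3)cccn12`: 93%

Compound 3 stands highest of the three, and both gaps to the others are beyond the scatter. Compound 4 `Cc1nc2c(OCc3ccccc3)cccn2c1NCc1ccccc1` differs from compound 3 in one place: benzyl in place of acetyl on a nitrogen on an aromatic ring. Among the compounds with values here, no pair of measured compounds shows this exchange, so its effect is unknown from the numbers in hand. Compound 3 is the only one of the three carrying a group on that nitrogen, and the two compounds without one spread widely in this assay. A loss beyond the scatter is expected, a number 38 percentage points lower from compound 3 to compound 4 (beyond the scatter). Compound 4 is estimated at 55%, in a range from 15% to 90%.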

Compound 4, a percentage reported as inhibition, in the whole organism at one dose (the size of the read-out at that dose, not a potency): 48%
Compound 4: the middle estimate sits 7 percentage points above what was measured; measured number inside the range.
By their numbers in this assay, from the lowest: compound 1; then compounds 4 and 2 (each within the scatter of the next); then compound 3.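

With benzyl in place of acetyl on a nitrogen on an aromatic ring, this assay gives a number 45 percentage points lower from compound 3 to compound 4 (beyond the scatter), the first direct sign that the group at this position strongly affects the read-out. The loss is only partial, as compound 4 still gives 48%. Nothing measured here explains the drop.

From the compounds shown here alone, whether it comes from losing the carbonyl or gaining the benzene ring stays open; an ethyl or benzoyl group on that nitrogen would separate the two. The free amine on the same core would add a reference with neither group.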